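The source may report more compounds than this note shows. Statements on the series, on what has been measured and on what is new or still open speak of the compounds shown alone.

Working notes on the series. Compound 2 `COc1ccc(Nc2ncnc3cc(OC)c(OCCCCC(=O)Nc4ccc(S(N)(=O)=O)cc4)cc23)cc1` sits at the limit of the assay rather than at a number: in a functional assay on A549 cells (Homo sapiens) for antiproliferative activity, read by MTT assay, with a stated time of 72 h (a lower number here means a stronger inhibitor, a higher number a weaker inhibitor), compound 2 gives > 40000 nM, which is a limit. Compound 1 `COc1cc2ncnc(Nc3cccc(F)c3)c2cc1OCCCCC(=O)Nc1ccc(S(N)(=O)=O)cc1` also gives > 40000 nM, again a limit. Compound 3 `COc1cc2ncnc(Nc3cccc(Cl)c3F)c2cc1OCCCCC(=O)Nc1ccc(S(N)(=O)=O)cc1` alone gives a number, 10500 nM. Both limits are the same, (the limit of > 40000 nM in this assay, at which 2 of the 3 values shown sit), so the step that the two limits leave unreadable from compound 1 to compound 2 cannot be read, whereas an at least 3.8-fold lower number from compound 2 to compound 3 (0.58 log units; beyond the scatter) is clear. Compound 4 `COc1cc2ncnc(Nc3ccc(C)cc3)c2cc1OCCCCC(=O)Nc1ccc(S(N)(=O)=O)cc1` keeps the shared core and changes only the ring on the nitrogen: methyl in place of methoxy on an aromatic carbon. Among the compounds with values here, no measured step touches this position; the readable steps swap the whole ring. The step that the limit leaves unreadable from compound 2 to compound 4 is therefore expected to stay within the scatter, and compound 4 is estimated at 50000 nM, between 15000 nM and 200000 nM.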

Compound 4, half-maximal inhibitory concentration: > 40000 nM
Compound 4 was reported as a limit; the forecaster's own chance of this, stated with the estimate: 70%; the middle value lies beyond the limit too.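

Methyl in place of methoxy at this position brings no number into reach in this assay, and the steps among compounds 1, 2 and 4 cannot be read, as all three sit at one limit: the limit of > 40000 nM in this assay, at which 3 of the 4 values shown sit.

The 4-methylphenyl ring in place of the 3-chloro-2-fluorophenyl ring gives an at least 3.8-fold higher number from compound 3 to compound 4 (0.58 log units; beyond the scatter). Among the compounds shown, a number appears only with the 3-chloro-2-fluorophenyl ring of compound 3.

From the compounds shown here alone, whether an amine or a carboxylic acid at this position would give a readable number stays open. So does the size of any difference between methoxy and methyl, which the limit hides.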